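Methyl for methoxy on the aryl ether of a xanthine core

The source may report more compounds than this note shows. Statements on the series, on what has been measured and on what is new or still open speak of the compounds shown alone.

Compounds measured so far:
compound 1, `Cn1c(=O)c2c(nc(COc3cccc(Br)c3)n2C)n(C)c1=O`, 148 nM
compound 2, `COc1cccc(OCc2nc3c(c(=O)n(C)c(=O)n3C)n2C)c1`, 1960 nM

In an in vitro assay on cells for inhibition of Amine oxidase [flavin-containing] B (Homo sapiens), read by coupled enzyme assay, with a stated time of 20 min (a higher number here means a weaker inhibitor, a lower number a stronger inhibitor), compound 2 gives the highest of the two numbers recorded; its nearest neighbour is compound 1, which gives 148 nM. Among the measured compounds shown here, the one measured step, a 13-fold higher number from compound 1 to compound 2 (1.12 log units; beyond the scatter), shows that a methoxy in place of a bromo on the aromatic carbon weakened inhibition considerably.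

Compound 3, `Cc1cccc(OCc2nc3c(c(=O)n(C)c(=O)n3C)n2C)c1`, has not yet been measured. It differs from compound 2 by methyl in place of methoxy on an aromatic carbon, placed on an aromatic carbon of a six-membered aromatic ring of carbon only, meta to a large group. For the measured compounds named here, no measured step covers methyl directly. The step from compound 1 to compound 2 bears on it only by analogy: removing the methoxy moves compound 3 back toward the unsubstituted-ether side of that change, but the methyl is not the bromo of compound 1. The account therefore expects a moderate step downward, a 3.9-fold lower number from compound 2 to compound 3 (0.59 log units; beyond the scatter), short of recovering the full gap.

The estimate for compound 3 in this assay is 500 nM, with a range from 150 nM to 1800 nM.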

Compound 3, half-maximal inhibitory concentration: 1230 nM
For compound 3 the middle estimate is 2.5-fold (0.39 log units) below the measured one; low and high end bracket the measured number.
By their numbers in this assay, from the lowest: compound 1; then compounds 3 and 2 (each within the scatter of the next).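

In this assay, methyl in place of methoxy on this aromatic carbon gives a 1.6-fold lower number from compound 2 to compound 3 (0.20 log units; within the scatter), so the two groups cannot be told apart at this position, even though the methoxy brings one hydrogen-bond acceptor and the methyl none. Methyl in place of bromo gives an 8.3-fold higher number from compound 1 to compound 3 (0.92 log units; beyond the scatter), a step that, like a 13-fold higher number from compound 1 to compound 2 (1.12 log units; beyond the scatter) before it, lies beyond the scatter, so compound 1 stands apart from both and the gap is not peculiar to methoxy. Nothing shown here explains why the compound with bromo differs from the other two.

The compounds shown leave open whether another halogen, such as chloro or iodo, would give a number close to that of compound 1 or close to those of compound 2 and compound 3. They also leave open how an amine, a carboxylic acid or a longer chain such as ethyl would read on this carbon, and whether the gap between bromo and the other two groups would persist with these groups elsewhere on the ring.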